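This account rests on a few compounds, and the source may have more. Where it says the series, first, only, none or still open, it means among the compounds named here.

Measured in an ADME assay on microsomes from liver (Mus musculus) for metabolic stability, read by LC-MS, with a stated time of 40 min, tested at 0.5 uM; a lower number here means slower removal, a higher number faster removal of the compound:
- compound 1 `O=C(Nc1cccc(S(=O)(=O)C2CCCC2)c1)c1cccnc1N1CCC(F)(F)CC1`: > 399 mL.min-1.g-1 (a limit)
- compound 2 `CC(C)(CO)S(=O)(=O)c1cccc(NC(=O)c2cccnc2N2CCC3(CC2)CC3)c1`: > 399 mL.min-1.g-1 (a limit)
- compound 3 `CC(C)(C)NS(=O)(=O)c1cccc(NC(=O)c2ccc(NC(C)(C)CO)cc2N2CCC3(CC2)CC3)n1`: > 399 mL.min-1.g-1 (a limit)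

Among the measured compounds shown here, the series so far shows (the limit of > 399 mL.min-1.g-1 in this assay, at which 3 of the 3 values shown sit). Compound 2 therefore stands at a limit and has no exact number.

Compound 4 `CC(C)(C)NS(=O)(=O)c1cccc(NC(=O)c2cccnc2N2CCC3(CC2)CC3)c1` carries (tert-butyl)amino in place of 1-(hydroxymethyl)-1-methylethyl on a sulfonyl sulfur. Compound 3 also carries the (tert-butyl)sulfamoyl group, and it gives the limit > 399 mL.min-1.g-1. For the measured compounds named here, no measured step gives a size for this change, so no direction can be assigned. The expected change is a step that the limit leaves unreadable from compound 2 to compound 4, with nothing expected beyond the usual scatter. For compound 4 the estimated value in this assay is 400 mL.min-1.g-1, with an expected range of 150 mL.min-1.g-1 to 800 mL.min-1.g-1.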

Compound 4, intrinsic clearance in microsomes: > 399 mL.min-1.g-1
Compound 4 was reported as a limit (the forecaster's own chance of this, stated with the estimate: 65%); the middle value is on the limit's open side.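

No step can be read from compound 2 to compound 4, because both stand at a limit: the limit of > 399 mL.min-1.g-1 in this assay, at which 4 of the 4 values shown sit.

Still open in this assay is whether (tert-butyl)sulfamoyl and (1-(hydroxymethyl)-1-methylethyl)sulfonyl differ at all, and what exact clearance any compound shown has.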